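Working notes: adding a methoxy to compound 3

The source may report more compounds than this note shows. Statements on the series, on what has been measured and on what is new or still open speak of the compounds shown alone.

Results from a functional assay on cells (Homo sapiens) for inhibition, read by MTT assay, with a stated time of 48 h (a lower number here means a stronger inhibitor, a higher number a weaker inhibitor), for the measured compounds:
compound 1 `O=C(CCCOc1no[n+]([O-])c1S(=O)(=O)c1ccccc1)NO` gives 22000 nM
compound 2 `O=C(CCCCCCOc1no[n+]([O-])c1S(=O)(=O)c1ccccc1)NO` has "not determined" (no result reported)
compound 3 `O=C(NO)c1ccc(Oc2no[n+]([O-])c2S(=O)(=O)c2ccccc2)cc1` gives 4350 nM

Only two of these compounds have a number. Compound 3 holds the lower of the two, and compound 1 stands higher by a gap beyond the scatter. Compound 2 offers no number for comparison.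

The next compound is compound 4 `COc1cc(C(=O)NO)ccc1Oc1no[n+]([O-])c1S(=O)(=O)c1ccccc1`, still unmeasured. For the measured compounds named here, its only structural change from compound 3 is methoxy in place of hydrogen on an aromatic carbon and the rest of the structure stays the same. Going by the values given here, no measured pair shows a change of this kind, so the data give no direct guide to its effect. The starting point is therefore compound 3 at 4350 nM with a wide margin on both sides. The expected 1.1-fold lower number from compound 3 to compound 4 (0.04 log units; within the scatter) is no move beyond the scatter in this assay and no firm direction is expected. For compound 4 the estimated value is 4000 nM with an expected range from 1500 nM to 12000 nM as the working figure.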

Compound 4, half-maximal inhibitory concentration: 1240 nM
Compound 4: the middle estimate sits 3.2-fold (0.51 log units) above what was measured, and the stated range ends above it.
By their numbers in this assay, from the lowest: compound 4; then compound 3; then compound 1.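

In this assay, for the compounds shown here, the change gives a 3.5-fold lower number from compound 3 to compound 4 (0.55 log units; beyond the scatter), the only step that can be read between compounds differing in one place. It shows that methoxy in place of hydrogen on this aromatic carbon, ortho to a large group and meta to a hydroxycarbamoyl group, is tolerated and moves the number downward by a modest step beyond the scatter. No measurement shown bears on the reason for this step.

From the compounds shown here alone, whether a hydroxy group, an amine, fluorine or a longer ether such as ethoxy on the same aromatic carbon would move the number in the same direction remains open. Also open, going by these compounds, is whether methoxy on another carbon of this ring would give a similar step.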